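Trichlorophenyl Swap in a Sulfonamide Series at the Limit

This account rests on a few compounds, and the source may have more. Where it says the series, first, only, none or still open, it means among the compounds named here.

Compound 1 `O=S(=O)(NC1=NCCN1C(=S)SN1CCn2c1nsc2=S)c1ccccc1` reaches only a limit in a functional assay on KYSE-510 cells (Homo sapiens) for antiproliferative activity, read by crystal violet staining, with a stated time of 96 h; on this read-out higher numbers stand for weaker inhibition of growth and lower numbers for stronger inhibition of growth: >= 20000 nM.
Compound 2 `COc1ccc(OC)c(S(=O)(=O)NC2=NCCN2C(=S)SN2CCn3c2nsc3=S)c1` reaches only a limit in this assay: >= 20000 nM.
Compound 3 `O=S(=O)(NC1=NCCN1C(=S)SN1CCn2c1nsc2=S)c1cccc(OC(F)(F)F)c1` reaches only a limit in this assay: >= 20000 nM.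

Compound 2 thus stands at the ceiling of the measurements, with no number beneath it, exactly as the other two do. Compound 4 `O=S(=O)(NC1=NCCN1C(=S)SN1CCn2c1nsc2=S)c1ccc(Cl)c(Cl)c1Cl` differs from compound 2 by 2,3,4-trichlorophenyl in place of 2,5-dimethoxyphenyl on a sulfonyl sulfur. The measured steps that bear on this change, a step that the two limits leave unreadable from compound 1 to compound 2 and a step that the two limits leave unreadable from compound 1 to compound 3, are both unreadable, since the limit of >= 20000 nM in this assay, at which 3 of the 3 values shown sit, holds every value shown. No size or direction in this assay can therefore be read from them. For compound 4 a limit is again expected, with an estimate of 20000 nM spanning 8000 nM to 20000 nM. The step of a number no higher from compound 2 to compound 4 (the limit leaves the size open) is expected to be none beyond the scatter.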

Compound 4, concentration for 50% growth inhibition: >= 20000 nM
Compound 4: a limit, no number (the forecaster's own chance of this, stated with the estimate: 75%); the middle value lies on the limit itself.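

No step can be read from compound 4 to compound 1 or compound 2, since all of them stay at one limit: the limit of >= 20000 nM in this assay, at which 4 of the 4 values shown sit.

The compounds shown leave open whether any group on the sulfonyl sulfur alters growth inhibition in this assay.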